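A few compounds are considered here, and "the series" means these few. Any claim that something is new, unique, unknown or untested is made for them only; others in the source may bear on it.

Of the compounds shown here, two have been measured so far. Compound 1 `CCn1c(=O)n(C2OC(CO)[C@@H](O)[C@H]2O)c2nc(N)nc(O)c21` carries an ethyl group on its core and an unprotected sugar; in a functional assay on the whole organism with Mus musculus as the target (on this read-out higher numbers stand for larger maximal responses and lower numbers for smaller maximal responses), compound 1 gives 82%. Compound 2 `C=CCn1c(=O)n([C@@H]2O[C@H](CO)[C@H]3OC(C)(CCC(=O)OCC)O[C@H]32)c2nc(N)nc(O)c21` differs from it in more than one place, and in this assay compound 2 gives 0%. Compound 1 thus stands highest of the two numbers, with the gap to compound 2 beyond the usual scatter.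

The unmeasured compound 3 `Nc1nc(O)c2c(n1)n(C1OC(CO)[C@@H](O)[C@H]1O)c(=O)n2C/C=C/c1ccccc1` keeps the unprotected sugar of compound 1 and changes only one place: 2-phenylethenyl in place of methyl on a saturated chain carbon bound to an aromatic nitrogen. Within the data shown here, since no single-change step between measured compounds is available, the size of this move rests on judgment alone. A considerably larger group on the saturated chain carbon bound to the aromatic nitrogen is expected to lower the maximal response, by a step of a number 37 percentage points lower from compound 1 to compound 3 (beyond the scatter) in this assay from compound 1 to compound 3, beyond the scatter but with wide uncertainty. For compound 3 the expected value in this assay is 45%, within a range from 10% to 85%.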

Compound 3, largest response reached (reported as maximal response), in percent of the reference or control that the assay uses: 5%
For compound 3 the middle estimate is 40 percentage points above the measured one; the whole stated range lies above it.
By their numbers in this assay, from the lowest: compounds 2 and 3 (each within the scatter of the next); then compound 1.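

Among these compounds, the step from compound 1 gives the first single-change reading at this position: with the unprotected sugar kept, 2-phenylethenyl in place of methyl on a saturated chain carbon bound to an aromatic nitrogen changes the result in this assay by a number 77 percentage points lower from compound 1 to compound 3 (beyond the scatter). The response seen with the smaller group therefore does not survive this enlargement, something compound 2 could not show, since it differs from compound 1 in more than one place. Nothing shown gives a reason for this loss.

The compounds shown leave open how a simple longer chain such as propyl or butyl would read at this place. They also leave open whether a saturated 3-phenylpropyl chain, or a chain ending in an amine or a carboxylic acid, would retain the response.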